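Swapping Trifluoromethyl for Isopropyl in a Cytotoxicity Series

The compounds below may be only part of what the source reports. "The series", "measured", "known", "first", "only" and "open" are said of these compounds alone.

In a functional assay on KB 3-1 cells (Homo sapiens) for cytotoxicity, read by MTT assay, with a stated time of 72 h (a higher number here means a weaker inhibitor, a lower number a stronger inhibitor), compound 1 `O=C1Nc2ccccc2/C1=N/NC(=S)Nc1ccc(C(=O)O)cc1` gives > 50000 nM as a limit of the assay, not a number. Within the data shown here, compound 2 `O=C1Nc2ccccc2/C1=N/NC(=S)Nc1ccc(C(F)(F)F)cc1` gives 8590 nM as the only actual number so far. Compound 3 `CC(C)c1ccc(NC(=S)N/N=C2\C(=O)Nc3ccccc32)cc1` has isopropyl in place of trifluoromethyl on an aromatic carbon and is otherwise the same. Among the measured compounds shown here, only one measured step bears on this: an at least 5.8-fold lower number from compound 1 to compound 2 (0.76 log units; beyond the scatter) with trifluoromethyl in place of carboxy. That step removed carboxy, not trifluoromethyl, so it sets no size for the new change, and no step beyond the scatter is expected in this assay in either direction. The expected outcome is a 1.2-fold lower number from compound 2 to compound 3 (0.09 log units; within the scatter) at the middle of the estimate. For compound 3 the estimate is 7000 nM with an expected range from 2500 nM to 20000 nM in this measurement.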

Compound 3, half-maximal inhibitory concentration: 9110 nM
Compound 3: the middle estimate sits 1.3-fold (0.11 log units) below what was measured, and the stated range covers the measured number.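

In this assay, isopropyl in place of trifluoromethyl gives a 1.1-fold higher number from compound 2 to compound 3 (0.03 log units; within the scatter), so this assay does not separate the two groups at this position. The step away from carboxy also holds with isopropyl, at an at least 5.4-fold lower number from compound 1 to compound 3 (0.73 log units; beyond the scatter), so it is not tied to trifluoromethyl alone. That size is only a minimum, as compound 1 stands at a limit of the assay and not at a number: the limit of > 50000 nM in this assay, at which 1 of the 3 values shown sits. Going by these compounds, whether an amine or a longer chain here would match compounds 2 and 3, or give a clearly lower number, stays open.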